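A few compounds are considered here, and "the series" means these few. Any claim that something is new, unique, unknown or untested is made for them only; others in the source may bear on it.

In an ADME assay on A549 cells (Homo sapiens) for cytotoxicity, read by resazurin assay, with a stated time of 48 h (on this read-out higher numbers stand for lower toxicity in this test and lower numbers for higher toxicity in this test), compound 1 `CC1(Nc2ccc(NC(=O)c3cc(Cl)ccc3O)c(Cl)c2)CCCC1` gives 157000 nM, compound 2 `O=C(Nc1ccc(NCc2ccc(Br)cc2)cc1Cl)c1cc(Cl)ccc1O` gives 40900 nM and compound 3 `O=C(Nc1ccc(NCc2cc(Cl)cc(Cl)c2)cc1Cl)c1cc(Cl)ccc1O` gives 13300 nM, the lowest number of the three. Compound 4 `CC(CCO)Nc1ccc(NC(=O)c2cc(Cl)ccc2O)c(Cl)c1` differs from compound 3 by one change: 3-hydroxy-1-methylpropyl in place of 3,5-dichlorobenzyl on a nitrogen on an aromatic ring. For the measured compounds named here, no measured compound carries this hydroxylated chain, so the closest guide is compound 1, which also lacks a benzyl group. The measured steps are a 12-fold lower number from compound 1 to compound 3 (1.07 log units; beyond the scatter) and a 3.8-fold lower number from compound 1 to compound 2 (0.58 log units; beyond the scatter), while the two benzyl groups differ by a 3.1-fold lower number from compound 2 to compound 3 (0.49 log units; beyond the scatter). Leaving the benzyl group is therefore expected to raise the number by a large step, and the estimated step is a 6.8-fold higher number from compound 3 to compound 4 (0.83 log units; beyond the scatter). The estimate for compound 4 is 90000 nM, with an expected range of 35000 nM to 250000 nM.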

Compound 4, half-maximal cytotoxic concentration: 200000 nM
Estimate against measurement, compound 4: 2.2-fold (0.35 log units) below; measured number inside the range.
By their numbers in this assay, from the lowest: compound 3; then compound 2; then compounds 1 and 4 (each within the scatter of the next).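

In this assay, 3-hydroxy-1-methylpropyl on the nitrogen gives a 15-fold higher number from compound 3 to compound 4 (1.18 log units; beyond the scatter) and a 4.9-fold higher number from compound 2 to compound 4 (0.69 log units; beyond the scatter), so this chain stands apart from both benzyl groups by more than the scatter. Against the ringed 1-methylcyclopentyl group it gives a 1.3-fold higher number from compound 1 to compound 4 (0.11 log units; within the scatter), within the scatter, so at this position these two non-benzyl groups are not told apart, even though only one of them carries a ring and a hydroxyl is present only in the other. Nothing available explains these differences. From the compounds shown here alone, whether an unsubstituted benzyl group or a longer chain on this nitrogen would fall with compound 1 and compound 4 or with compound 2 and compound 3 remains open.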